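This account rests on a few compounds, and the source may have more. Where it says the series, first, only, none or still open, it means among the compounds named here.

Measured compounds:
compound 1, `CN(C)CCn1c(N)c(-c2nc3ccccc3n2C)c2nc(C#N)c(C#N)nc21`: in a functional assay on Raji cells (Homo sapiens) for antiproliferative activity, read by MTT assay, with a stated time of 48 h (on this read-out lower numbers stand for stronger inhibition and higher numbers for weaker inhibition), compound 1 gives 46500 nM
compound 2, `CCN(CC)CCn1c(N)c(-c2nc3ccccc3n2C)c2nc(C#N)c(C#N)nc21`: in this assay compound 2 gives 2080 nM
compound 3, `CN(C)CCCCn1c(N)c(-c2nc3cc(Cl)ccc3[nH]2)c2nc(C#N)c(C#N)nc21`: in this assay compound 3 gives 950 nM

Compound 4, `CCN(CC)CCCCn1c(N)c(-c2nc3cc(Cl)ccc3[nH]2)c2nc(C#N)c(C#N)nc21`, is not yet measured. Within the pair already in hand, the change diethylamino in place of dimethylamino on a saturated chain carbon, two bonds along the chain from an aromatic nitrogen gave a 22-fold lower number from compound 1 to compound 2 (1.35 log units; beyond the scatter). Compound 4 carries the same kind of change on the core of compound 3, (diethylamino in place of dimethylamino on a saturated chain carbon, four bonds along the chain from an aromatic nitrogen); the place differs in that the amine sits four bonds along the chain from the aromatic nitrogen rather than two. How the core of compound 3 differs from that of compound 1 is not broken down here. Compound 3 already stands lowest of the three measured values, so the step from compound 3 to compound 4 is expected to be smaller than the earlier one, estimated at a 3.8-fold lower number from compound 3 to compound 4 (0.58 log units; beyond the scatter), resting on compound 1 to compound 2 showing a 22-fold lower number from compound 1 to compound 2 (1.35 log units; beyond the scatter). Compound 4 is therefore expected to give about 250 nM in this assay, within 60 nM to 900 nM.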

Compound 4, half-maximal inhibitory concentration: 720 nM
For compound 4 the middle estimate is 2.9-fold (0.46 log units) below the measured one, and the stated range covers the measured number.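

On the core of compound 3, diethylamino in place of dimethylamino gives a 1.3-fold lower number from compound 3 to compound 4 (0.12 log units; within the scatter), so no effect of the change can be read on this core in this assay. The change therefore does not carry over in size from the core of compound 1 to the core of compound 3, and the two steps differ: the same change on two cores in this assay, a 22-fold lower number (1.35 log units; beyond the scatter) from compound 1 to compound 2 and a 1.3-fold lower number (0.12 log units; within the scatter) from compound 3 to compound 4, 17-fold (1.23 log units) apart, beyond the scatter of two such steps

This rests on one pair per core and does not show which difference between the two pairs sets the gap, whether the place of the amine, four bonds along the chain rather than two, or the rest of the core. From the compounds shown here alone, it remains open whether the size of the step follows chain length or the other parts of the core. Also open, going by these compounds, is how a cyclic amine such as piperidine or a longer chain would behave at this place.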